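The source may hold more compounds than are shown below. What is called first, only, known or untested is meant among the compounds shown, and "the series" means these compounds.

Measured in a functional assay on SW1573 cells (Homo sapiens) for antiproliferative activity, read by sulforhodamine B assay, with a stated time of 48 h; a higher number here means a weaker inhibitor of growth, a lower number a stronger inhibitor of growth:
compound 1 `CCCCCCC(C#CC(=O)OC)O/C=C/C(=O)OC`: 3300 nM
compound 2 `COC(=O)C#CC(O/C=C/C(=O)OC)C(C)(C)C`: 3000 nM

Within the data shown here, compound 1 is one of only two measured compounds, and its number cannot be told apart from the other one. Among the measured compounds shown here, the single measured step, a 1.1-fold lower number from compound 1 to compound 2 (0.04 log units; within the scatter), puts tert-butyl in place of hexyl.

Compound 3 `CCCCCCCCCCC(C#CC(=O)OC)O/C=C/C(=O)OC` keeps the core of compound 1 and lengthens its chain: butyl in place of hydrogen on a saturated chain carbon, seven bonds along the chain from an oxygen on an unsaturated carbon and a triple-bonded carbon. For the measured compounds named here, the measured step replaces the hexyl group outright rather than extending it, so it is only a loose guide, and no compound with a longer chain has been measured. The data therefore give no reason to expect a step beyond the scatter in this assay, in either direction, though the uncertainty is wide. The expected change is a 1.1-fold lower number from compound 1 to compound 3 (0.04 log units; within the scatter). For compound 3 the estimated value is 3000 nM, with a range of 1200 nM to 7500 nM.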

Compound 3, concentration for 50% growth inhibition: 2000 nM
Beside the measured number, compound 3's estimate is 1.5-fold (0.18 log units) above it, within the range that was stated.
By their numbers in this assay, from the lowest: compounds 3, 2 and 1 (each within the scatter of the next).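

In this assay, the added butyl gives a 1.7-fold lower number from compound 1 to compound 3 (0.22 log units; within the scatter), so the two numbers cannot be told apart. Among these compounds, until now the only measured step at this chain had replaced hexyl with tert-butyl; this result shows that extending the chain, with butyl in place of hydrogen seven bonds along the chain from an oxygen on an unsaturated carbon and a triple-bonded carbon, also gives no step beyond the scatter. No evidence is available that bears on this result.

The compounds shown leave open whether a longer chain would still stay within the scatter of compound 1, and what a much shorter group such as methyl would do in its place. They also leave open how a chain ending in an amine or a carboxylic acid would read in this assay.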